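The source may hold more compounds than are shown below. What is called first, only, known or untested is meant among the compounds shown, and "the series" means these compounds.

Measured so far:
- compound 1 `Cc1cnc(NC(=O)c2cc(Oc3cnc(C(=O)N(C)C)cn3)c3cc(C)oc3c2)cn1`: < 8 mL/min/kg (a limit)
- compound 2 `Cc1cnc(NC(=O)c2cc(Oc3ccc(S(C)(=O)=O)cc3)c3cn(C)nc3c2)cn1`: < 8 mL/min/kg (a limit)

In an in vitro ADME assay on microsomes from liver (Homo sapiens) for metabolic stability (a lower number here means slower removal, a higher number faster removal of the compound), compound 2 gives < 8 mL/min/kg, which is a limit of the assay and not a number. Compound 1 gives < 8 mL/min/kg, which is also a limit. The whole record in this assay is therefore (the limit of < 8 mL/min/kg in this assay, at which 2 of the 2 values shown sit), and no exact clearance is available for either compound.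

The next compound is compound 3 `Cc1cnc(NC(=O)c2cc(Oc3ccc(S(=O)(=O)N(C)C)cc3)c3cn(C)nc3c2)cn1`, which differs from compound 2 in one place: dimethylamino in place of methyl on a sulfonyl sulfur. Dimethylamino stands in place of methyl on a sulfonyl sulfur, so methylsulfonyl becomes dimethylsulfamoyl. For the measured compounds named here, no measured pair shows this change, so its size cannot be read from the data and the expectation remains loose. A small rise is expected, with a step no larger than the usual scatter or only slightly beyond it. The estimated change is an at least 1.1-fold higher number from compound 2 to compound 3 (0.05 log units; that floor lies within the scatter). The assay may well report only a limit again. For compound 3 the estimated clearance is 9 mL/min/kg, with an expected range of 6 mL/min/kg to 20 mL/min/kg.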

Compound 3, clearance: < 8 mL/min/kg
Compound 3: only a limit was reported; the forecaster's own chance of this, stated with the estimate: 50%; at least 1.1-fold (0.05 log units) between middle value and limit.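

In this assay compound 3 gives < 8 mL/min/kg, which is a limit and not a number. Compound 2 is also reported only as a limit, so no step can be read between compound 2 and compound 3. The compounds shown leave open how their clearances compare, since none has an exact value: the limit of < 8 mL/min/kg in this assay, at which 3 of the 3 values shown sit.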